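Benzylamino nucleosides: halogen swap on the phenyl ring

This account rests on a few compounds, and the source may have more. Where it says the series, first, only, none or still open, it means among the compounds named here.

Measured so far in this assay:
compound 1, `OC[C@H]1O[C@@H](n2cnc3c(NCc4ccccc4F)ncnc32)[C@H](O)[C@@H]1O`: 4600 nM
compound 2, `OC[C@H]1O[C@@H](n2cnc3c(NCc4ccc(Cl)cc4)ncnc32)[C@H](O)[C@@H]1O`: 10200 nM

Among the measured compounds shown here, in a functional assay on CCRF-CEM cells (Homo sapiens) for antiproliferative activity, with a stated time of 72 h (on this read-out lower numbers stand for stronger inhibition and higher numbers for weaker inhibition), compound 2 stands at the highest of the two numbers; its only neighbour is compound 1, and the single measured step is a 2.2-fold higher number from compound 1 to compound 2 (0.35 log units; beyond the scatter). Compound 3, `OC[C@H]1O[C@@H](n2cnc3c(NCc4cccc(Br)c4)ncnc32)[C@H](O)[C@@H]1O`, differs from compound 2 by 3-bromophenyl in place of 4-chlorophenyl on a saturated chain carbon bound to a nitrogen on an aromatic ring. The step from compound 1 to compound 2 is the only one that touches the same place, and it moved the number modestly while exchanging both the halogen and its position on the phenyl. It does not say how a 3-bromophenyl will read against a 4-chlorophenyl, so the change is expected to sit within or near the scatter, with a slight lean toward a lower number because a 2.2-fold higher number from compound 1 to compound 2 (0.35 log units; beyond the scatter) shows this position is not silent. The expected step is a 1.5-fold lower number from compound 2 to compound 3 (0.16 log units; within the scatter). For compound 3 the estimated value in this assay is 7000 nM, with a range of 3000 nM to 18000 nM.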

Compound 3, half-maximal inhibitory concentration: 5000 nM
Compound 3: the middle estimate sits 1.4-fold (0.15 log units) above what was measured; low and high end bracket the measured number.
By their numbers in this assay, from the lowest: compounds 1 and 3 (each within the scatter of the next); then compound 2.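

In this assay, among the compounds shown here, a 2.0-fold lower number from compound 2 to compound 3 (0.31 log units; beyond the scatter) is a modest change, and it leaves the 4-chlorophenyl of compound 2 as the one group that stands apart, with the weakest number of the three. The 2-fluorophenyl and 3-bromophenyl groups read alike, with a 1.1-fold higher number from compound 1 to compound 3 (0.04 log units; within the scatter) as the step, so two different halogens at two different places on the phenyl ring give one level within the scatter. No supporting data bear on why these groups read as they do.

Every step here exchanges the halogen and its place on the ring together, so the two remain unseparated; a 4-bromophenyl or a 3-chlorophenyl would pull them apart. Also open, on these data alone, is how an unsubstituted phenyl, or a phenyl carrying an amine or a carboxylic acid, would read in this assay against these halogenated compounds.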